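Moving the methyl group: from compound 2 to compound 3

The source may hold more compounds than are shown below. What is called first, only, known or untested is meant among the compounds shown, and "the series" means these compounds.

Among the compounds with values here, in a functional assay on K562 cells (Homo sapiens) for antiproliferative activity, read by trypan blue exclusion, with a stated time of 48 h, tested at 10 uM (on this read-out lower numbers stand for less inhibition of growth and higher numbers for more inhibition of growth at the one concentration tested), compound 1 `NC(=O)c1cc(Cl)ccc1NC(=O)/C=C/c1ccccc1Br` gives 49% and compound 2 `Cc1ccccc1/C=C/C(=O)Nc1ccc(Cl)cc1C(N)=O` gives 52.2%, so compound 2 stands level with the only other measured compound. Compound 3 `Cc1cccc(/C=C/C(=O)Nc2ccc(Cl)cc2C(N)=O)c1` has 3-methylphenyl in place of 2-methylphenyl on a double-bonded chain carbon bound to a double-bonded chain carbon. Within the data shown here, the single measured step, a number 3.2 percentage points higher from compound 1 to compound 2 (within the scatter), exchanged bromo for methyl on an aromatic carbon and offers only indirect guidance, since no measured pair tests this move. The expected step is a number 2.2 percentage points lower from compound 2 to compound 3 (within the scatter), with no change beyond the scatter anticipated. For compound 3 the estimate is 50%, with an expected range of 36% to 64%.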

Compound 3, percent growth inhibition at one concentration: 37.8%
Compound 3: middle estimate off by 12.2 percentage points, on the high side; low and high end bracket the measured number.
By their numbers in this assay, from the lowest: compound 3; then compounds 1 and 2 (each within the scatter of the next).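

In this assay, within the data shown here, the two methylphenyl groups are not interchangeable: 3-methylphenyl in place of 2-methylphenyl gives a number 14.4 percentage points lower from compound 2 to compound 3 (beyond the scatter) although both have the same atoms, joined differently. 3-methylphenyl in place of 2-bromophenyl gives a number 11.2 percentage points lower from compound 1 to compound 3 (beyond the scatter) and so also lies beyond the scatter, unlike the exchange of bromo for methyl between the earlier compounds. Nothing at hand gives a reason for this difference. Still open, from the compounds shown here alone, is how an aminophenyl or a carboxyphenyl would read in place of 3-methylphenyl on the same chain carbon.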